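The source may report more compounds than this note shows. Statements on the series, on what has been measured and on what is new or still open speak of the compounds shown alone.

Measured compounds:
compound 1 `COc1ccc(C(=O)c2sc3nc(-c4cccs4)ccc3c2N)cc1`, 0.77 ug/mL
compound 2 `COc1ccc(C(=O)c2sc3nc(-c4cccs4)ccc3c2N)c(OC)c1`, 0.52 ug/mL
compound 3 `COc1ccccc1C(=O)c1oc2cc(-c3ccccc3)cc(O)c2c1C`, 0.09 ug/mL

These three were tested in a functional assay on WI-38 VA13 cells (Homo sapiens) for cytotoxicity (a higher number here means that more compound is needed for the effect, a lower number that less compound is needed), and compound 3 gives the lowest number of the three, beyond the scatter from both others. Compound 1 and compound 2 share one core; compound 3 has a different core, and how the two cores differ is not broken down here.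

Compound 4 `COc1ccc(OC)c(C(=O)c2oc3cc(-c4ccccc4)cc(O)c3c2C)c1` is not yet measured. Its change from compound 3 is methoxy in place of hydrogen on an aromatic carbon. Compound 2 arose from compound 1 by the same kind of change, (methoxy in place of hydrogen on an aromatic carbon), though there the new group sat ortho to a large group and meta to a methoxy group, while in compound 4 it sits meta to a large group and para to a methoxy group. That earlier step gave a 1.5-fold lower number from compound 1 to compound 2 (0.17 log units; within the scatter).

Resting on that step, compound 4 is expected to move about as little from compound 3, roughly a 1.1-fold lower number from compound 3 to compound 4 (0.05 log units; within the scatter). The estimate for compound 4 in this assay is 0.08 ug/mL, between 0.04 ug/mL and 0.16 ug/mL.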

Compound 4, half-maximal effective concentration: 0.09 ug/mL
Beside the measured number, compound 4's estimate is 1.1-fold (0.05 log units) below it; the range from low to high includes it.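

In this assay, methoxy in place of hydrogen on the aromatic ring gives no change at the digits printed from compound 3 to compound 4 (within the scatter). On these two cores, the change therefore behaves alike as far as this cytotoxicity read-out can tell: the same change on two cores in this assay, a 1.5-fold lower number (0.17 log units; within the scatter) from compound 1 to compound 2 and no change at the digits printed (within the scatter) from compound 3 to compound 4, 1.5-fold (0.17 log units) apart, within the scatter of two such steps. This does not show that the change is without effect or that it would carry to a further core, as two steps are few, and the new group sits in a different place in each, so the effects of core and place cannot be separated.

The compounds shown leave open whether a longer chain, such as ethoxy, would behave like methoxy here. They also leave open whether an amine or a carboxylic acid in that place would shift the number.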